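A few compounds are considered here, and "the series" means these few. Any claim that something is new, unique, unknown or untested is made for them only; others in the source may bear on it.

Compound 3 `C/C(=N\NC(N)=S)C1c2ccccc2CCN1S(=O)(=O)c1ccc(C)cc1` in a functional assay on HepG2 cells (Homo sapiens) for cytotoxicity, read by crystal violet staining, with a stated time of 3 days (on this read-out lower numbers stand for stronger inhibition and higher numbers for weaker inhibition), gives 46 ug/mL, the highest of the two numbers recorded; the nearest is compound 2 `COc1ccc(S(=O)(=O)N2CCc3cc(OC)c(OC)cc3C2/C(C)=N/NC(N)=S)cc1`, which in this assay gives 10.5 ug/mL. Compound 1 `COc1cc2c(cc1OC)C(/C(C)=N/NC(N)=S)N(S(=O)(=O)c1ccc([N+](=O)[O-])cc1)CC2` in this assay gives > 50 ug/mL, which is a limit of the assay rather than a number (the limit of > 50 ug/mL in this assay, at which 1 of the 3 values shown sits). Compound 4 `C/C(=N\NC(N)=S)C1c2ccccc2CCN1S(=O)(=O)c1ccc([N+](=O)[O-])cc1` differs from compound 3 by nitro in place of methyl on an aromatic carbon. Among the measured compounds shown here, the one measured step that bears on this change runs the other way: an at least 4.7-fold lower number from compound 1 to compound 2 (0.67 log units; beyond the scatter). Read in reverse, swapping in nitro raised the number beyond the scatter, so the expected step is a 1.4-fold higher number from compound 3 to compound 4 (0.15 log units; within the scatter), a rise in this assay that may pass the limit. Compound 4 is therefore expected to give about 65 ug/mL, within 30 ug/mL to 150 ug/mL.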

Compound 4, half-maximal inhibitory concentration: 32.3 ug/mL
Estimate against measurement, compound 4: 2.0-fold (0.30 log units) above, within the range that was stated.
By their numbers in this assay, from the lowest: compound 2; then compounds 4 and 3 (each within the scatter of the next). At a limit, above all of these: compound 1.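

In this assay there is a 1.4-fold lower number from compound 3 to compound 4 (0.15 log units; within the scatter), so on this core the change from 4-methylphenyl to 4-nitrophenyl does not move the read-out beyond the scatter. The earlier step at this position, an at least 4.7-fold lower number from compound 1 to compound 2 (0.67 log units; beyond the scatter), involved methoxy rather than methyl and a different core, so the two steps do not compare directly. With nitro, compound 1 remains a limit and not a number: the limit of > 50 ug/mL in this assay, at which 1 of the 4 values shown sits.

On these data alone, the methoxy group on the core of compound 3 remains open. So does the reading of an amine or a carboxylic acid at this position.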